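Adding Chloro to the Pyridine Ring of Compound 2

This account rests on a few compounds, and the source may have more. Where it says the series, first, only, none or still open, it means among the compounds named here.

Compound 1 `O=C(CCCCCCc1ccccc1)c1nc(-c2ccco2)no1`: 933 nM in an assay on HEK-293T cells for inhibition of diacylglycerol lipase-alpha (Homo sapiens), read by colorimetric assay; a lower number here means a stronger inhibitor, a higher number a weaker inhibitor
Compound 2 `O=C(CCCCCCc1ccccc1)c1nc(-c2ccccn2)no1`: 2750 nM

Compound 2 gives the higher of the two numbers, compound 1 the lower; the step of a 2.9-fold higher number from compound 1 to compound 2 (0.47 log units; beyond the scatter) swaps the furan ring for a pyridine ring. Compound 3 `O=C(CCCCCCc1ccccc1)c1nc(-c2cccc(Cl)n2)no1` keeps the core of compound 2 and differs by chloro in place of hydrogen on an aromatic carbon, next to the ring nitrogen. For the measured compounds named here, no measured step concerns a chloro substituent, so the only step offers no guidance for this change. Compound 3 is therefore estimated to give 2500 nM, between 900 nM and 7000 nM, meaning an expected step of a 1.1-fold lower number from compound 2 to compound 3 (0.04 log units; within the scatter), within the scatter.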

Compound 3, half-maximal inhibitory concentration: > 10000 nM
Compound 3: a limit, no number; the forecaster's own chance of this, stated with the estimate: 5%; middle value at least 4.0-fold (0.60 log units) from the limit.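

Placing chloro next to the ring nitrogen is not a neutral change: it gives an at least 3.6-fold higher number from compound 2 to compound 3 (0.56 log units; beyond the scatter). Measured against the furan-2-yl group, 6-chloropyridin-2-yl gives an at least 10-fold higher number from compound 1 to compound 3 (1.03 log units; beyond the scatter), so this single added atom turns a modest step into a large one. The value of compound 3 is a limit, not a number: the limit of > 10000 nM in this assay, at which 1 of the 3 values shown sits.

On these data alone, whether the loss belongs to chloro itself or to any group at this position stays open. A fluoro, methyl or amino group in the same place would help separate the two.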